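A few compounds are considered here, and "the series" means these few. Any claim that something is new, unique, unknown or untested is made for them only; others in the source may bear on it.

Measured compounds:
compound 1, `COc1nc(-c2cc3ccccc3o2)cc(-c2cccc3ccccc23)c1C#N`: 359000 nM
compound 2, `CCOc1nc(-c2cc3ccccc3o2)cc(-c2cccc3ccccc23)c1C#N`: 344000 nM
compound 3, `COc1nc(-c2cc3ccccc3o2)cc(-c2ccc(Br)cc2)c1C#N`: 298000 nM

All three values come from a functional assay on aorta (strain Wistar) for inhibition, with Thoracic aorta (Rattus norvegicus) as the target; on this read-out lower numbers stand for stronger inhibition and higher numbers for weaker inhibition. Compound 1 and compound 2 differ in one place, (methyl in place of hydrogen on a saturated chain carbon bound to an oxygen on an aromatic ring), and this step gave a 1.0-fold lower number from compound 1 to compound 2 (0.02 log units; within the scatter). The difference between the core of compound 1 and the core of compound 3 is not broken down here; the values of compound 3 and compound 2 lie within the scatter of one another.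

Compound 4, `CCOc1nc(-c2cc3ccccc3o2)cc(-c2ccc(Br)cc2)c1C#N`, is compound 3 carrying the same kind of change at the same place, (methyl in place of hydrogen on a saturated chain carbon bound to an oxygen on an aromatic ring). Because a 1.0-fold lower number from compound 1 to compound 2 (0.02 log units; within the scatter) lay within the scatter, the new step is expected to be as small. The step from compound 3 to compound 4 is expected to be a 1.0-fold higher number from compound 3 to compound 4 (0.00 log units; within the scatter). Compound 4 is thus estimated at 300000 nM, with a likely range of 150000 nM to 600000 nM.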

Compound 4, half-maximal inhibitory concentration: 227000 nM
For compound 4 the middle estimate is 1.3-fold (0.12 log units) above the measured one; the range from low to high includes it.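

In this assay, the change from methoxy to ethoxy on the core of compound 3 gave a 1.3-fold lower number from compound 3 to compound 4 (0.12 log units; within the scatter), and 4-bromophenyl in place of naphthalen-1-yl on the ethoxy compounds gave a 1.5-fold lower number from compound 2 to compound 4 (0.18 log units; within the scatter). The change from methoxy to ethoxy reads the same on both cores: the same change on two cores in this assay, a 1.0-fold lower number (0.02 log units; within the scatter) from compound 1 to compound 2 and a 1.3-fold lower number (0.12 log units; within the scatter) from compound 3 to compound 4, 1.3-fold (0.10 log units) apart, within the scatter of two such steps. On these two cores it therefore carries over as a step within the scatter, but this does not show that the added methyl has any effect of its own, or that the same would hold on a third core.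

As far as these compounds go, it remains open whether a longer chain or an amine in place of the ethoxy group would move the value beyond the scatter. From the compounds shown here alone, a carboxylic acid in place of the nitrile is equally open.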